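The source may report more compounds than this note shows. Statements on the series, on what has been measured and on what is new or still open speak of the compounds shown alone.

Compound 1 `COC[C@H](C(C)C)C(c1ccc(O)c(OC)c1)c1ccc(O)c(OC)c1` gives 72000 nM in a functional assay on HL-60 cells (Homo sapiens) for cytotoxicity, read by WST assay, with a stated time of 48 h; a lower number here means a stronger inhibitor, a higher number a weaker inhibitor. Compound 2 `COC[C@@H](C)[C@H](C)C(c1ccc(O)c(OC)c1)c1ccc(O)c(OC)c1` gives 73000 nM in this assay, and a 1.0-fold higher number from compound 1 to compound 2 (0.01 log units; within the scatter). Compound 3 `COc1cc(C(c2ccc(O)c(OC)c2)[C@H](C)[C@H](C)CO)ccc1O` gives only a limit of the assay in this assay, > 100000 nM. On the numbers shown compound 3 stands apart only by giving a limit, (the limit of > 100000 nM in this assay, at which 1 of the 3 values shown sits), and both steps leading to it lie inside the scatter. Compound 4 `COc1cc(C(c2ccc(O)c(OC)c2)[C@@H](C)C(C)C)ccc1O` differs from compound 3 in that (1,2-dimethylpropyl in place of 2-(hydroxymethyl)-1-methylpropyl on a saturated chain carbon bound to two aromatic carbons). The measured steps bearing on this are an at least 1.3-fold higher number from compound 1 to compound 3 (0.14 log units; that floor lies within the scatter) and an at least 1.3-fold higher number from compound 2 to compound 3 (0.13 log units; that floor lies within the scatter), both changes at the same chain and both small. No step beyond the scatter is therefore expected in this assay, and compound 4 is estimated at 80000 nM, within 40000 nM to 160000 nM, a step of an at least 1.2-fold lower number from compound 3 to compound 4 (0.09 log units; that floor lies within the scatter).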

Compound 4, half-maximal inhibitory concentration: 20000 nM
Compound 4: middle estimate off by 4.0-fold (0.60 log units), on the high side; measured number outside the range, below it.
By their numbers in this assay, from the lowest: compound 4; then compounds 1 and 2 (each within the scatter of the next). At a limit, above all of these: compound 3.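

With 1,2-dimethylpropyl on the saturated chain carbon bound to two aromatic carbons, this position gives its first steps beyond the scatter in this assay: a 3.7-fold lower number from compound 2 to compound 4 (0.56 log units; beyond the scatter) and a 3.6-fold lower number from compound 1 to compound 4 (0.56 log units; beyond the scatter). Replacing 2-(hydroxymethyl)-1-methylpropyl with this oxygen-free chain gives an at least 5.0-fold lower number from compound 3 to compound 4 (0.69 log units; beyond the scatter). Compound 3 gives only a limit of the assay: the limit of > 100000 nM in this assay, at which 1 of the 4 values shown sits.

Going by these compounds, whether the lower number follows from the all-carbon chain as such stays open. Also open, on these data alone, is what an amine or a longer alkyl chain would give at this position.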